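This account rests on a few compounds, and the source may have more. Where it says the series, first, only, none or still open, it means among the compounds named here.

Measured so far in a functional assay on IMR-32 cells (Homo sapiens) for cytotoxicity, read by sulforhodamine B assay, with a stated time of 48 h; a lower number here means a stronger inhibitor, a higher number a weaker inhibitor:
- compound 1, `COc1cc(C2CC(c3ccc(Br)cc3)=NN2C(C)=O)cc(OC)c1OC`: 3130 nM
- compound 2, `CC(=O)N1N=C(c2ccc(Br)cc2)CC1c1cccc(Cl)c1Cl`: 45700 nM
- compound 3, `COc1cc(C2CC(c3ccco3)=NN2C(C)=O)cc(OC)c1OC`: 9870 nM

Compound 1 and compound 2 share a core, but the difference between the two cores is not broken down here. Compound 3 differs from compound 1 by furan-2-yl in place of 4-bromophenyl on a carbon with a double bond to nitrogen, and this change gave a 3.2-fold higher number from compound 1 to compound 3 (0.50 log units; beyond the scatter). Compound 4, `CC(=O)N1N=C(c2ccco2)CC1c1cccc(Cl)c1Cl`, is not yet measured; it differs from compound 2 by furan-2-yl in place of 4-bromophenyl on a carbon with a double bond to nitrogen. The surroundings are not identical: in compound 2 the ring atom two ring bonds away bears a group of 8 heavy atoms, whereas in compound 1 it bears a large group, so the change is the same kind of change rather than the same. Compound 2 already gives the highest number of the three, and compound 4 is expected to move by a 2.6-fold higher number from compound 2 to compound 4 (0.42 log units; beyond the scatter), because the same kind of change gave a 3.2-fold higher number from compound 1 to compound 3 (0.50 log units; beyond the scatter). Compound 4 is therefore estimated at 120000 nM, between 40000 nM and 400000 nM.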

Compound 4, half-maximal inhibitory concentration: 62200 nM
Compound 4: middle estimate off by 1.9-fold (0.29 log units), on the high side; the measured number falls inside the stated range.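

In this assay, furan-2-yl in place of 4-bromophenyl gave a 1.4-fold higher number from compound 2 to compound 4 (0.13 log units; within the scatter), so on the core of compound 2 the swap leaves no difference that can be read. Set beside the step on the core of compound 1, the two steps do not differ by more than repeated measurements would: the same change on two cores in this assay, a 3.2-fold higher number (0.50 log units; beyond the scatter) from compound 1 to compound 3 and a 1.4-fold higher number (0.13 log units; within the scatter) from compound 2 to compound 4, 2.3-fold (0.36 log units) apart, within the scatter of two such steps. For the compounds shown here, this shows that the change carries across these two cores without a readable difference between the steps, but it rests on only two pairs and does not show that the steps are equal or that they would hold on any other core.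

The compounds shown leave open how a pyridine ring or a phenyl ring carrying an amine would behave on the carbon with a double bond to nitrogen. They also leave open what a longer chain in place of the acetyl group would do.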